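This account rests on a few compounds, and the source may have more. Where it says the series, first, only, none or still open, it means among the compounds named here.

Measured so far in an assay on cells for displacement of a labelled ligand from adenosine receptor A3 (Homo sapiens), read by scintillation counting and radioligand binding, with a stated time of 180 min; a lower number here means a stronger inhibitor, a higher number a weaker inhibitor:

Compound 1, `CN1CCN(c2nc(-c3ccc(Cl)c(Cl)c3)nc3[nH]cnc23)CC1`: 39.8 nM
Compound 2, `Clc1ccc(-c2nc(N3CCCCC3)c3nc[nH]c3n2)cc1Cl`: 79.4 nM
Compound 3, `CN1CCN(c2nc(-c3ccc(Cl)c(C(F)(F)F)c3)nc3[nH]cnc23)CC1`: 794 nM

Compound 1 gives the lowest of the three numbers. Its nearest neighbour is compound 2, where the step of a 2.0-fold higher number from compound 1 to compound 2 (0.30 log units; within the scatter) lies within the scatter, so the two cannot be ranked. Compound 3 stands furthest away: the step of a 20-fold higher number from compound 1 to compound 3 (1.30 log units; beyond the scatter) is large and well beyond the scatter, and it arises from a single change on the dichlorophenyl ring of compound 1.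

Compound 4, `CN1CCN(c2nc(-c3cc(Cl)ccc3Cl)nc3[nH]cnc23)CC1`, has not yet been measured. It differs from compound 1 only in that ring: 2,5-dichlorophenyl in place of 3,4-dichlorophenyl on an aromatic carbon. The two compounds share every atom; only the arrangement on the phenyl ring changes.

Within the data shown here, only the step from compound 1 to compound 3 bears on this, since it too alters the phenyl ring, and it was large and towards weaker binding. The step from compound 1 to compound 2 concerns a different part of the molecule. Among the measured compounds shown here, no measured pair shows the same rearrangement, so the direction is uncertain, but the sensitivity of this ring suggests a step beyond the scatter, most likely to a higher number. The estimate for compound 4 in this assay is therefore 250 nM, between 60 nM and 1500 nM, a step of a 6.3-fold higher number from compound 1 to compound 4 (0.80 log units; beyond the scatter).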

Compound 4, inhibition constant: 251 nM
Compound 4: the middle estimate sits 1.0-fold (0.00 log units) below what was measured; measured number inside the range.
By their numbers in this assay, from the lowest: compounds 1 and 2 (each within the scatter of the next); then compound 4; then compound 3.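

In this assay, rearranging the two chloro groups on the phenyl ring gives a 6.3-fold higher number from compound 1 to compound 4 (0.80 log units; beyond the scatter), with no atom gained or lost. The earlier change from chloro to trifluoromethyl, in compound 3, replaced a group, so it could not show whether the arrangement of the groups matters on its own. Compound 4 shows that it does: 3,4-dichlorophenyl and 2,5-dichlorophenyl are not interchangeable here, although the size of this effect is known from this single pair. Nothing available explains why the rearrangement weakens binding.

As far as these compounds go, it remains open whether 2,5-dichlorophenyl would bring a similar loss alongside the piperidin-1-yl group of compound 2. From the compounds shown here alone, it is also open how a phenyl ring with a single chloro group, or with a methoxy group or a nitrile instead, would compare with compound 1.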